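A few compounds are considered here, and "the series" means these few. Any claim that something is new, unique, unknown or untested is made for them only; others in the source may bear on it.

Compound 1 `CC1=C2CC(C)(C)/C=C/C(=O)/C(C)=C\C3=C[C@H](C)C[C@]3(O2)[C@@]1(O)C(F)(F)F` gives 26000 nM
Compound 2 `CC1=C2CC(C)(C)[C@@H](C)CC(=O)/C(C)=C\C3=C[C@H](C)C[C@]3(O2)C1=O` gives 26000 nM

In an ADME assay on HepG2 cells (Homo sapiens) for cytotoxicity, read by CellTiter-Glo, with a stated time of 72 h (on this read-out lower numbers stand for an effect already at smaller amounts and higher numbers for an effect only at larger amounts of compound), compound 1 stands level with compound 2, the two values lying within the scatter. Compound 3 `CC1=C2CC(C)(C)/C=C/C(=O)/C(C)=C\C3=C[C@H](C)C[C@]3(O2)[C@@]1(O)C#N` keeps the core of compound 1, with cyano in place of trifluoromethyl on a saturated ring carbon. For the measured compounds named here, no measured pair shows this change, so the data give no direct guide. No step beyond the scatter is expected in this assay, in either direction, from the starting point of compound 1 at 26000 nM in this read-out. The expected change is a 1.2-fold lower number from compound 1 to compound 3 (0.07 log units; within the scatter) on this estimate. For compound 3 the estimated value is 22000 nM (9000 nM to 50000 nM).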

Compound 3, half-maximal effective concentration: 26000 nM
Estimate against measurement, compound 3: 1.2-fold (0.07 log units) below; measured number inside the range.
By their numbers in this assay, from the lowest: compounds 1, 2 and 3 (each within the scatter of the next).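

In this assay, for the compounds shown here, cyano in place of trifluoromethyl on a saturated ring carbon gives no change at the digits printed from compound 1 to compound 3 (within the scatter) and so supplies the first matched pair at this position, which compounds 1 and 2 alone could not provide. On the core of compound 1, the read-out therefore tolerates this exchange of trifluoromethyl for cyano, including the added hydrogen-bond acceptor. Nothing available explains why the two groups read alike. Still open, going by these compounds, is whether an amine, a carboxylic acid or a longer chain on this carbon would leave the number equally unmoved.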